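This account rests on a few compounds, and the source may have more. Where it says the series, first, only, none or still open, it means among the compounds named here.

Measured so far in a functional assay on Bel-7402 cells (Homo sapiens) for cytotoxicity, read by MTT assay; on this read-out higher numbers stand for weaker inhibition and lower numbers for stronger inhibition:
compound 1, `Cc1ccccc1Nc1nc(C)c(C(=O)/C=C/c2ccc(Cl)cc2)s1`, reaches only a limit of the assay: > 25000 nM
compound 2, `Cc1nc(Nc2cccc(Cl)c2)sc1C(=O)/C=C/c1ccc(Cl)cc1`, reaches only a limit of the assay: > 25000 nM
compound 3, `COc1cccc(/C=C/C(=O)c2sc(Nc3ccccc3C)nc2C)c1`, reaches only a limit of the assay: > 25000 nM

All three share one core, and none of them gives a number. Compound 2 differs from compound 1 by 3-chlorophenyl in place of 2-methylphenyl on a nitrogen on an aromatic ring, and the result is a step that the two limits leave unreadable from compound 1 to compound 2. Compound 3 differs from compound 1 by 3-methoxyphenyl in place of 4-chlorophenyl on a double-bonded chain carbon bound to a double-bonded chain carbon, and the result is a step that the two limits leave unreadable from compound 1 to compound 3.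

Compound 4, `COc1cccc(/C=C/C(=O)c2sc(Nc3cccc(Cl)c3)nc2C)c1`, has not yet been measured. It differs from compound 3 by 3-chlorophenyl in place of 2-methylphenyl on a nitrogen on an aromatic ring, the same change that was made from compound 1 to compound 2; the two cores differ as just told for compound 3 against compound 1, so the change is of the same kind on a different core. Going by the values given here, because the limit of > 25000 nM in this assay, at which 3 of the 3 values shown sit, shows every value so far at the limit of this assay, compound 4 is also expected to stay at that limit, with an expected step that the limit leaves unreadable from compound 3 to compound 4. The estimate for compound 4 is 35000 nM, in the range 20000 nM to 100000 nM.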

Compound 4, half-maximal inhibitory concentration: > 25000 nM
Compound 4: no number, only a limit (the forecaster's own chance of this, stated with the estimate: 85%); the middle value does not contradict the limit.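

Compound 4, like compound 2 and compound 3, reaches only a limit, so neither step to compound 4 can be read. The compounds shown leave open whether any change on this shared core gives a measurable value in this assay.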